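A Methoxyphenyl Amide in Place of the Benzyl Amide

A few compounds are considered here, and "the series" means these few. Any claim that something is new, unique, unknown or untested is made for them only; others in the source may bear on it.

Within the data shown here, compound 2 `COc1ccc2c(=O)c(/C=C/C(=O)NCc3ccccc3)coc2c1` gives 13600 nM in a functional assay on Huh-7 cells (Homo sapiens) for inhibition, read by MTT assay, with a stated time of 48 h (a higher number here means a weaker inhibitor, a lower number a stronger inhibitor), the highest of the three numbers measured so far. Compound 1 `O=C(/C=C/c1coc2cc(O)ccc2c1=O)NCc1ccccc1` gives 4690 nM and compound 3 `COc1ccc(CNC(=O)/C=C/c2coc3cc(OC)ccc3c2=O)cc1` gives 7570 nM, so a 2.9-fold higher number from compound 1 to compound 2 (0.46 log units; beyond the scatter) lies beyond the scatter while a 1.8-fold lower number from compound 2 to compound 3 (0.25 log units; within the scatter) stays within it. Compound 4 `COc1ccc2c(=O)c(/C=C/C(=O)Nc3ccccc3OC)coc2c1` differs from compound 2 by 2-methoxyphenyl in place of benzyl on an amide-type nitrogen. Among the measured compounds shown here, no measured step alters the group on the amide-type nitrogen itself; the closest comparison, the step from compound 2 to compound 3, only added a methoxy to the benzyl ring and stayed within the scatter. A shift beyond the scatter in this assay is therefore not expected, though the data give little guidance. Compound 4 is estimated at 12000 nM, between 4000 nM and 36000 nM. This expected step is a 1.1-fold lower number from compound 2 to compound 4 (0.05 log units; within the scatter).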

Compound 4, half-maximal inhibitory concentration: 32300 nM
The estimate for compound 4 lay 2.7-fold (0.43 log units) below the measured number; low and high end bracket the measured number.
By their numbers in this assay, from the lowest: compounds 1, 3 and 2 (each within the scatter of the next, the first and the last beyond it); then compound 4.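

Replacing the whole group on the amide-type nitrogen moves the number beyond the scatter in this assay (a 2.4-fold higher number from compound 2 to compound 4 (0.38 log units; beyond the scatter)), whereas adding a methoxy to the benzyl ring did not. The step from the 4-methoxybenzyl amide runs the same way (a 4.3-fold higher number from compound 3 to compound 4 (0.63 log units; beyond the scatter)), so 2-methoxyphenyl gives the weaker inhibitor in both comparisons. Nothing available explains this shift.

The two steps cannot separate the effect of removing the benzyl carbon from that of the methoxy on the ring. From the compounds shown here alone, how an unsubstituted phenyl or a longer chain such as 2-phenylethyl would behave on this nitrogen remains open.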